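This account rests on a few compounds, and the source may have more. Where it says the series, first, only, none or still open, it means among the compounds named here.

Working notes on the urea series sharing the core of compound 1 `O=C(NCCCOc1ccc2nc(O)ccc2c1)N(C1CCCCC1)C1CC1`. In a functional assay on the whole organism for inhibition, with Rattus norvegicus as the target, at a dose of 30 mg/kg by the oral route (on this read-out lower numbers stand for less inhibition and higher numbers for more inhibition at the one dose given (going by the name of the read-out)), compound 1 gives 15%. Compound 2 `O=C(NCCCOc1ccc2nc(O)ccc2c1)N(C1CC1)[C@@H]1CCC[C@@H](O)C1` gives 0% in this assay, and compound 3 `O=C(NCCCOc1ccc2nc(O)ccc2c1)N(C1CC1)[C@H]1CCCC[C@H]1O` gives 19%. Compound 3 has the highest number of the three, but the step of a number 4 percentage points higher from compound 1 to compound 3 (within the scatter) is within the scatter, so those two cannot be ordered; only a number 19 percentage points higher from compound 2 to compound 3 (beyond the scatter) sets compound 3 clearly apart, as does a number 15 percentage points lower from compound 1 to compound 2 (beyond the scatter) for compound 2.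

Compound 4 `CCCCO[C@H]1CCCC[C@@H]1N(C(=O)NCCCOc1ccc2nc(O)ccc2c1)C1CC1` differs from compound 3 by 2-butoxycyclohexyl in place of 2-hydroxycyclohexyl on an amide-type nitrogen. Going by the values given here, no measured step swaps the hydroxy for an ether, so nothing bears directly on this change. The nearest guide is that the ring without any hydroxy, compound 1, sits within scatter of compound 3, given a number 4 percentage points higher from compound 1 to compound 3 (within the scatter), so loss of the donor by itself need not move this assay much. Among the compounds with values here, the butoxy chain adds carbon with no precedent here. Compound 4 is therefore expected to move by about a number 7 percentage points lower from compound 3 to compound 4 (within the scatter), likely within the scatter, and is estimated at 12%, between 0% and 30%.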

Compound 4, a percentage reported as inhibition, in the whole organism at one dose (the size of the read-out at that dose, not a potency): 19%
Compound 4: the middle estimate sits 7 percentage points below what was measured; the range from low to high includes it.
By their numbers in this assay, from the lowest: compound 2; then compounds 1, 3 and 4 (each within the scatter of the next).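

In this assay, 2-butoxycyclohexyl in place of 2-hydroxycyclohexyl on the amide-type nitrogen gives no change at the digits printed from compound 3 to compound 4 (within the scatter), so at this position the hydrogen-bond donor of the 2-hydroxycyclohexyl group is not required to retain the read-out at this dose. Butoxy in place of hydrogen on the saturated ring carbon also stays inside the scatter, with a number 4 percentage points higher from compound 1 to compound 4 (within the scatter), which shows that this position accepts a chain of this length without a clear change. The one clear separation remains with the 3-hydroxycyclohexyl group, as 2-butoxycyclohexyl in its place gives a number 19 percentage points higher from compound 2 to compound 4 (beyond the scatter).

No available evidence accounts for these results. Going by these compounds, it remains open whether an amine or a carboxylic acid on the butoxy chain, or a longer chain at the same place, would lift the number beyond the scatter.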